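Adding a Methoxy Group to the Phenyl Ring

The source may report more compounds than this note shows. Statements on the series, on what has been measured and on what is new or still open speak of the compounds shown alone.

Measured compounds:
compound 1 `O=C(Nc1nc2ccc(F)cc2s1)c1cn(-c2ccccc2)nc1-c1ccccc1` — 3250 nM
compound 2 `O=C(Nc1nc2ccc(Cl)cc2s1)c1cn(-c2ccccc2)nc1-c1ccccc1` — 3690 nM
compound 3 `Cc1ccc2nc(NC(=O)c3cn(-c4ccccc4)nc3-c3ccccc3)sc2c1` — 15700 nM

In a functional assay on PC-3 cells (Homo sapiens) for cytotoxicity, read by MTT assay, with a stated time of 72 h (on this read-out lower numbers stand for stronger inhibition and higher numbers for weaker inhibition), compound 1 has the lowest number of the three, though compound 2 sits within the scatter of it (a 1.1-fold higher number from compound 1 to compound 2 (0.06 log units; within the scatter)), while compound 3 lies further off (a 4.8-fold higher number from compound 1 to compound 3 (0.68 log units; beyond the scatter)). Compound 4 `COc1ccc(-c2nn(-c3ccccc3)cc2C(=O)Nc2nc3ccc(F)cc3s2)cc1` differs from compound 1 by methoxy in place of hydrogen on an aromatic carbon. Among the measured compounds shown here, none of the measured steps touches this phenyl ring; all of them swap a group on the shared core, and even the largest, a 4.3-fold higher number from compound 2 to compound 3 (0.63 log units; beyond the scatter), is only modest. With no direct guide, the step from compound 1 to compound 4 is expected to stay close to the scatter: a 1.1-fold lower number from compound 1 to compound 4 (0.03 log units; within the scatter). Compound 4 is therefore estimated at 3000 nM, with a range from 1200 nM to 8000 nM.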

Compound 4, half-maximal inhibitory concentration: 4930 nM
For compound 4 the middle estimate is 1.6-fold (0.22 log units) below the measured one; the range from low to high includes it.
By their numbers in this assay, from the lowest: compounds 1, 2 and 4 (each within the scatter of the next); then compound 3.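

Phenyl to 4-methoxyphenyl is the first change shown on this ring, as the earlier steps all altered a group on the shared core. In this assay it gives a 1.5-fold higher number from compound 1 to compound 4 (0.18 log units; within the scatter), so this place, para to a large group, carries a methoxy with no shift beyond the scatter in this one example. Nothing shown here explains this result. Going by these compounds, whether an amine, a carboxylic acid or a longer chain in the same place would stay as close remains open, as does whether methoxy would behave the same way on compound 2 or compound 3.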